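Cyclopropyl for trifluoroethoxy at the aryl piperazine

The source may hold more compounds than are shown below. What is called first, only, known or untested is meant among the compounds shown, and "the series" means these compounds.

Measured so far:
compound 1 `CNC(=O)c1cccnc1NCCCN1CCN(c2ccccc2OC)CC1`: 3.16 nM
compound 2 `CN(C)C(=O)c1cccnc1NCCCN1CCN(c2ccccc2OCC(F)(F)F)CC1`: 15.9 nM

In a functional assay on aorta for antagonist activity at Alpha-1D adrenergic receptor (Rattus norvegicus) (on this read-out higher numbers stand for weaker binding and lower numbers for tighter binding), compound 2 gives 15.9 nM, the higher of the two numbers; compound 1 gives 3.16 nM, and that gap lies beyond the scatter. For the measured compounds named here, compound 1 and compound 2 differ in more than one place, so no single step connects them.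

Compound 3 `CN(C)C(=O)c1cccnc1NCCCN1CCN(c2ccccc2C2CC2)CC1` is not yet measured. It differs from compound 2 by cyclopropyl in place of 2,2,2-trifluoroethoxy on an aromatic carbon, on an aromatic carbon ortho to a large group. Nothing measured here separates the effect of that change, so no step beyond the scatter is expected: from compound 2 to compound 3 the estimated step is a 1.3-fold higher number from compound 2 to compound 3 (0.10 log units; within the scatter). Compound 3 is expected at 20 nM, within 5 nM to 80 nM.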

Compound 3, dissociation constant: 63.1 nM
Compound 3: middle estimate off by 3.2-fold (0.50 log units), on the low side; the range from low to high includes it.
By their numbers in this assay, from the lowest: compound 1; then compound 2; then compound 3.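

In this assay, for the compounds shown here, this aromatic carbon ortho to a large group responds to its substituent: cyclopropyl in place of 2,2,2-trifluoroethoxy gives a 4.0-fold higher number from compound 2 to compound 3 (0.60 log units; beyond the scatter), the first single-place step. The exchange lowers both the heavy-atom count, from 6 to 3, and the hydrogen-bond acceptor count, from 1 to 0, and this one step does not separate the two. No evidence on hand bears on the origin of the step.

On these data alone, it remains open how an ethyl group or a nitrile would read on this aromatic carbon. The gap between compound 1 and compound 2 also remains unassigned between the amide and the aromatic substituent.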